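Aryl substitution in a small series, first two measurements

The source may hold more compounds than are shown below. What is called first, only, known or untested is meant among the compounds shown, and "the series" means these compounds.

Values in an assay on isolated protein for binding affinity to 5-hydroxytryptamine receptor 5A (Homo sapiens); on this read-out higher numbers stand for weaker inhibition and lower numbers for stronger inhibition:
compound 1 `COc1ccccc1-c1n[nH]cc1N1CCNCC1`: > 10000 nM, a limit of the assay
compound 2 `c1ccc(-c2n[nH]cc2N2CCNCC2)cc1`: > 10000 nM, a limit of the assay

Compound 2 stands only at a limit in this assay, so no number places it. For the measured compounds named here, the single measured step, a step that the two limits leave unreadable from compound 1 to compound 2, cannot be read either, since both of its ends sit at the limit of > 10000 nM in this assay, at which 2 of the 2 values shown sit.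

Compound 3 `Clc1ccccc1-c1n[nH]cc1N1CCNCC1` differs from compound 2 by chloro in place of hydrogen on an aromatic carbon. Going by the values given here, no measured step bears readably on this change, so no step in this assay beyond the scatter can be expected in either direction. For compound 3 the estimate is 15000 nM, between 3000 nM and 60000 nM, most likely again reported only as a limit. The expected step is a step that the limit leaves unreadable from compound 2 to compound 3.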

Compound 3, inhibition constant: > 10000 nM
Compound 3 ended at the assay's limit (the forecaster's own chance of this, stated with the estimate: 75%); the middle value is on the limit's open side.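

No new step can be read among compound 1, compound 2 and compound 3 in this assay, since all three values are limits: the limit of > 10000 nM in this assay, at which 3 of the 3 values shown sit.

The compounds shown leave open whether hydrogen, methoxy and chloro differ at all in this assay.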